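The source may report more compounds than this note shows. Statements on the series, on what has been measured and on what is new or still open speak of the compounds shown alone.

The compounds measured in an assay on isolated protein for inhibition of Amine oxidase [flavin-containing] B (Homo sapiens), read by fluorescence and Amplex Red, with a stated time of 30 min (on this read-out lower numbers stand for stronger inhibition and higher numbers for weaker inhibition), so far:

Compound 1, `C(=N/Nc1nc(-c2ccccc2)cs1)\c1ccc(N2CCCC2)cc1`, gives > 1000000 nM in this assay, a limit of the assay rather than a number.
Compound 2, `Brc1ccc(-c2csc(N/N=C/c3ccc(N4CCCC4)cc3)n2)cc1`, gives > 1000000 nM in this assay, again a limit and not a number.
Compound 3, `Clc1ccc(-c2csc(N/N=C/c3ccc(N4CCCC4)cc3)n2)cc1`, gives 761000 nM in this assay.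

Compound 1 therefore stands at the limit of this assay, together with compound 2, as the line the limit of > 1000000 nM in this assay, at which 2 of the 3 values shown sit, records, and only compound 3 returns a number. The step that the two limits leave unreadable from compound 1 to compound 2 cannot be read because both ends are limits. The step of an at least 1.3-fold lower number from compound 1 to compound 3 (0.11 log units; that floor lies within the scatter) and the step of an at least 1.3-fold lower number from compound 2 to compound 3 (0.11 log units; that floor lies within the scatter) are each floors that lie within the scatter.

Compound 4, `Fc1ccc(-c2csc(N/N=C/c3ccc(N4CCCC4)cc3)n2)cc1`, differs from compound 1 by fluoro in place of hydrogen on an aromatic carbon. The two steps that bear on it, a halogen entering at the same place, read in one case as unreadable and in the other as a floor within the scatter, so the direction and size of the step in this assay cannot be fixed from them. Compound 4 is expected to sit near the limit of this assay, with a step of a number no higher from compound 1 to compound 4 (the limit leaves the size open) judged as none beyond the scatter. The estimate for compound 4 is 1000000 nM, ranging from 400000 nM to 3000000 nM.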

Compound 4, half-maximal inhibitory concentration: 426000 nM
Estimate against measurement, compound 4: 2.3-fold (0.37 log units) above; low and high end bracket the measured number.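

In this assay, within the data shown here, fluoro on the aromatic carbon para to a large group gives the first steps at this position that lie beyond the scatter: an at least 2.3-fold lower number from compound 1 to compound 4 (0.37 log units; beyond the scatter), and an at least 2.3-fold lower number from compound 2 to compound 4 (0.37 log units; beyond the scatter). Both are floors, so a halogen at this position can lower the number measurably, but the true size of each step remains hidden; among the halogens, the comparison with chloro gives a 1.8-fold lower number from compound 3 to compound 4 (0.25 log units; within the scatter), which lies within the scatter and does not separate fluoro from chloro. The change from phenyl to 4-fluorophenyl therefore brings compound 4 to a measured number, yet the unsubstituted and bromo compounds remain unresolved: the limit of > 1000000 nM in this assay, at which 2 of the 4 values shown sit.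

On these data alone, how far compound 1 and compound 2 really lie from compound 4 stays open, and with it whether bromo differs from the other two halogens at all. The compounds shown also leave open what a methoxy group, a nitrile or a trifluoromethyl group would do at this position, and whether any change elsewhere on the shared core would bring a much lower number.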